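This account rests on a few compounds, and the source may have more. Where it says the series, first, only, none or still open, it means among the compounds named here.

Measured compounds in an ADME assay on Huh-7 cells (Homo sapiens) for cytotoxicity, read by MTT assay, with a stated time of 4 h, at 37 degrees C; on this read-out higher numbers stand for lower toxicity in this test and lower numbers for higher toxicity in this test:
compound 1, `Cn1c(=O)c(-c2c(Br)cccc2Br)cc2c(N)nc(Nc3ccccc3)nc21`, gives 800 nM
compound 2, `Nc1nc(Nc2ccccc2)nc2[nH]c(=O)c(-c3c(Br)cccc3Br)cc12`, gives 166000 nM
compound 3, `CCCOCCNc1nc(N)nc2c1cc(-c1ccc(F)cc1)c(=O)n2C`, gives 54300 nM

Compound 1 and compound 2 differ by hydrogen in place of methyl on an aromatic nitrogen, and this change made the step of a 210-fold higher number from compound 1 to compound 2 (2.32 log units; beyond the scatter). Compound 4, `CCCOCCNc1nc(N)nc2[nH]c(=O)c(-c3ccc(F)cc3)cc12`, is not yet measured. It stands to compound 3 as compound 2 stands to compound 1, by hydrogen in place of methyl on an aromatic nitrogen. The surroundings are not identical: in compound 1 the site is meta to a 2,6-dibromophenyl group, in compound 3 meta to a 4-fluorophenyl group, so this is the same kind of change rather than the same change. The difference between the two cores is not broken down here; compound 3 gives a higher number than compound 1 and a lower number than compound 2. Because the earlier step was a 210-fold higher number from compound 1 to compound 2 (2.32 log units; beyond the scatter), the expected step is a 5.5-fold higher number from compound 3 to compound 4 (0.74 log units; beyond the scatter), of the same direction though smaller, since compound 3 already starts high. For compound 4 a value of about 300000 nM is estimated, between 80000 nM and 1500000 nM.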

Compound 4, half-maximal cytotoxic concentration: 130000 nM
The estimate for compound 4 lay 2.3-fold (0.36 log units) above the measured number, within the range that was stated.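

Taking the methyl off the aromatic nitrogen in this assay again gives a higher number, with a 2.4-fold higher number from compound 3 to compound 4 (0.38 log units; beyond the scatter), but the size of the step does not carry from one core to the other: the same change on two cores in this assay, a 210-fold higher number (2.32 log units; beyond the scatter) from compound 1 to compound 2 and a 2.4-fold higher number (0.38 log units; beyond the scatter) from compound 3 to compound 4, 87-fold (1.94 log units) apart, beyond the scatter of two such steps. On these two pairs, only the direction carries over, with hydrogen giving the higher number and thus lower toxicity in this test. What sets the size is not shown, as the compound 1 and compound 3 pair differs in more than one place and two pairs cannot separate those differences.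

Open, as far as these compounds go, is whether the large step belongs to the 2,6-dibromophenyl group, to the phenylamino group or to the two together; a compound pairing the 2,6-dibromophenyl group with the propoxyethylamino chain, and its 4-fluorophenyl counterpart bearing the phenylamino group, would separate them. Also open, from the compounds shown here alone, is how an ethyl group or a longer chain on that nitrogen would compare with methyl and hydrogen on either core.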